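This account rests on a few compounds, and the source may have more. Where it says the series, first, only, none or still open, it means among the compounds named here.

Compound 1 `CCCCC[Se]c1nc([Se]CCCCC)c2ccccc2n1` and compound 2 `CCCCC[Se]c1nc(NCc2ccccc2)c2ccccc2n1` share one core. In a functional assay on HT-29 cells (Homo sapiens) for cytotoxicity, read by MTT assay, with a stated time of 72 h (a higher number here means a weaker inhibitor of growth, a lower number a stronger inhibitor of growth), compound 1 reaches only the assay limit, > 100000 nM. In this assay, among the measured compounds shown here, compound 2 gives 72700 nM, the only number recorded. The step of an at least 1.3-fold lower number from compound 1 to compound 2 (0.13 log units; that floor lies within the scatter) is bounded by the limit of > 100000 nM in this assay, at which 1 of the 2 values shown sits. Compound 3 `CSc1nc(NCc2ccccc2)c2ccccc2n1` differs from compound 2 by a group of 2 heavy atoms (1 carbon, 1 sulfur; no ring) in place of a group of 6 heavy atoms (5 carbon, 1 selenium; no ring), on an aromatic carbon. For the measured compounds named here, no measured step alters this group; the single step measured changes a different group and sits near the scatter, so a step of about a 1.1-fold higher number from compound 2 to compound 3 (0.04 log units; within the scatter) is expected. Compound 3 is therefore estimated at 80000 nM, between 30000 nM and 250000 nM.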

Compound 3, concentration for 50% growth inhibition: 36500 nM
Estimate against measurement, compound 3: 2.2-fold (0.34 log units) above, within the range that was stated.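

Among the compounds shown here, this is the first measured step at the aromatic carbon between two ring nitrogen atoms, where methylsulfanyl replaces the group of 6 heavy atoms that holds selenium. In this assay the exchange gives a 2.0-fold lower number from compound 2 to compound 3 (0.30 log units; within the scatter), so the two groups are not told apart at this position. Nothing shown gives a cause for this step.

The exchange alters the chain and swaps selenium for sulfur at once, and the compounds shown do not separate the two. Going by these compounds, how an amine or a carboxylic acid would read at this position also stays open.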